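The source may hold more compounds than are shown below. What is called first, only, known or untested is meant among the compounds shown, and "the series" means these compounds.

Measured so far:
Compound 1 `CCc1cc(C(C)=O)c(O)cc1OCCCCCCC#N`: 73%
Compound 2 `C=CCc1cc(C(C)=O)c(O)cc1OCCCCCC#N`: 41%

Going by the values given here, only two compounds have been measured in an assay on isolated protein for binding affinity to leukotriene B4 receptor 1 (Homo sapiens), tested at 1 uM; on this read-out higher numbers stand for more inhibition at the one concentration tested (going by the name of the read-out) and lower numbers for less inhibition. Compound 1 gives 73%, and compound 2 gives 41%, which is the lower of the two numbers, sitting a gap beyond the usual scatter under compound 1. Among the compounds with values here, no single-change step between measured compounds exists here, so the size of any step is not yet known from data.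

Compound 3 `C=CCc1cc(C(C)=O)c(O)cc1OCCCCCCC#N` is compound 2 with one change: cyanomethyl in place of cyano on a saturated chain carbon, five bonds along the chain from an oxygen on an aromatic ring. This lengthens the chain that ends in the nitrile by one carbon, bringing that chain to the same length as in compound 1. Since compound 1, carrying the longer chain, gave 73%, a step upward from compound 2 is expected, of moderate size, as a number 19 percentage points higher from compound 2 to compound 3 (beyond the scatter). Compound 3 is therefore estimated at 60%, with a range from 35% to 80%.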

Compound 3, a percentage reported as inhibition, at one concentration (the size of the read-out at that concentration, not a potency): 63%
Compound 3: the middle estimate sits 3 percentage points below what was measured; the measured number falls inside the stated range.
By their numbers in this assay, from the lowest: compound 2; then compounds 3 and 1 (each within the scatter of the next).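

In this assay, cyanomethyl in place of cyano, on a saturated chain carbon five bonds along the chain from an oxygen on an aromatic ring, gives a number 22 percentage points higher from compound 2 to compound 3 (beyond the scatter) as the first measured single-change step. The length of the chain ending in the nitrile therefore matters at this position, at least for these two compounds. With that chain unchanged, vinyl in place of methyl on a saturated chain carbon bound to an aromatic carbon gives a number 10 percentage points lower from compound 1 to compound 3 (within the scatter) and so has no effect that can be told apart from the usual spread of repeat measurements.

Going by these compounds, whether a still longer chain, or a carboxylic acid in place of the nitrile, would raise or lower the number remains open. No available measurement explains either step.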